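The source may hold more compounds than are shown below. What is called first, only, known or untested is meant among the compounds shown, and "the series" means these compounds.

Measured in a functional assay on HCT-8 cells (Homo sapiens) for cytotoxicity; a lower number here means that less compound is needed, a higher number that more compound is needed for the effect:
- compound 1 `COC1=C(C)C(=O)/C(=C(O)/C=C/c2ccc(F)cc2)C(=O)C1(C)C`: 3.6 ug/mL
- compound 2 `COC1=C(C)C(=O)/C(=C(O)/C=C/c2cccc3ccccc23)C(=O)C1(C)C`: 2.3 ug/mL

In this assay, compound 1 at 3.6 ug/mL and compound 2 at 2.3 ug/mL lie within the scatter of each other. Compound 3 `COC1=C(C)C(=O)/C(=C(O)/C=C/c2ccco2)C(=O)C1(C)C` is not yet measured. It differs from compound 1 as follows: furan-2-yl in place of 4-fluorophenyl on a double-bonded chain carbon bound to a double-bonded chain carbon. In words, furan-2-yl stands in place of 4-fluorophenyl on a double-bonded chain carbon bound to a double-bonded chain carbon. Among the measured compounds shown here, no measured step bears directly on this change. The expected outcome in this assay is a 1.1-fold higher number from compound 1 to compound 3 (0.05 log units; within the scatter), with no step beyond the scatter anticipated. For compound 3 the estimated value is 4 ug/mL, with an expected range of 1.5 ug/mL to 10 ug/mL.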

Compound 3, concentration for half-maximal effect: 17.5 ug/mL
For compound 3 the middle estimate is 4.4-fold (0.64 log units) below the measured one, outside the stated range (above it).
By their numbers in this assay, from the lowest: compounds 2 and 1 (each within the scatter of the next); then compound 3.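

In this assay, furan-2-yl in place of 4-fluorophenyl on a double-bonded chain carbon bound to a double-bonded chain carbon gives a 4.9-fold higher number from compound 1 to compound 3 (0.69 log units; beyond the scatter) on the shared core. Among the compounds shown here, compound 1 and compound 2 lie within the scatter of each other, so only this step shows that the group at this place can move the number beyond the scatter. Nothing at hand explains the step.

The compounds shown do not separate the ring oxygen from the change in ring size. As far as these compounds go, how an unsubstituted phenyl or thiophen-2-yl would read at this place remains open.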